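Replacing the isopropylcarbamoyl group of compound 1

The source may hold more compounds than are shown below. What is called first, only, known or untested is meant among the compounds shown, and "the series" means these compounds.

Compound 1 `Cc1cc(C(=O)NC(C)C)nn1Cc1cc(Cl)ccc1OCc1ccccc1` carries an isopropylcarbamoyl group on the shared core. Within the data shown here, in an assay on CHO-K1 cells for displacement of a labelled ligand from prostaglandin E2 receptor EP1 subtype (Homo sapiens) (a higher number here means a weaker inhibitor, a lower number a stronger inhibitor), compound 1 gives 126 nM, the highest number of the three measured so far. Compound 2 `Cc1cc(C(=O)Nc2ccccc2)nn1Cc1cc(Cl)ccc1OCc1ccccc1` gives 39.8 nM and compound 3 `Cc1cc(C(=O)NCc2ccccc2)nn1Cc1cc(Cl)ccc1OCc1ccccc1` gives 39.8 nM. The two measured steps from compound 1 both replace the isopropyl on the amide-type nitrogen: a 3.2-fold lower number from compound 1 to compound 2 (0.50 log units; beyond the scatter) and a 3.2-fold lower number from compound 1 to compound 3 (0.50 log units; beyond the scatter). Between the two larger groups there is no difference to speak of: no change at the digits printed from compound 2 to compound 3 (within the scatter).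

Compound 4 `Cc1cc(NC(=O)OC(C)(C)C)nn1Cc1cc(Cl)ccc1OCc1ccccc1` is not yet measured. It differs from compound 1 by (tert-butoxycarbonyl)amino in place of isopropylcarbamoyl on an aromatic carbon. Among the measured compounds shown here, this change does not vary the group on the amide-type nitrogen but alters the whole attachment at the aromatic carbon, so none of the measured steps bears on it directly; the series offers no step in which the isopropylcarbamoyl itself is replaced. For the measured compounds named here, with no guiding step, the expectation for compound 4 is a number near that of compound 1, and the expected step of a 1.6-fold higher number from compound 1 to compound 4 (0.20 log units; within the scatter) is taken as within the scatter, with the uncertainty wide on both sides. Compound 4 is therefore estimated at 200 nM in this assay, within a range from 50 nM to 1000 nM.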

Compound 4, half-maximal inhibitory concentration: 25.1 nM
For compound 4 the middle estimate is 8.0-fold (0.90 log units) above the measured one, and the stated range ends above it.
By their numbers in this assay, from the lowest: compounds 4, 2 and 3 (each within the scatter of the next); then compound 1.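

Earlier steps varied only the group on the amide-type nitrogen, whereas here the whole attachment on the aromatic carbon changes, with the nitrogen rather than the carbonyl now bound to the ring, and in this assay the number still falls, a 5.0-fold lower number from compound 1 to compound 4 (0.70 log units; beyond the scatter). The (tert-butoxycarbonyl)amino group has no ring, yet it cannot be separated from the two ring-bearing amides, with a 1.6-fold lower number from compound 3 to compound 4 (0.20 log units; within the scatter) and a 1.6-fold lower number from compound 2 to compound 4 (0.20 log units; within the scatter), so among these compounds a phenyl or benzyl group is not needed to reach this level at this position. No measurement available here accounts for the result.

Compound 4 changes the linkage and the end group together, so the step from compound 1 does not show how much each contributes, and an isopropyl carbamate or a tert-butyl amide would be needed to separate the two. From the compounds shown here alone, it also remains open how this position responds to a free amine or a carboxylic acid in place of these groups, and whether a benzyl carbamate would give a lower number than the tert-butyl one.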